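The source may hold more compounds than are shown below. What is called first, only, known or untested is meant among the compounds shown, and "the series" means these compounds.

In a functional assay on HT-29 cells (Homo sapiens) for inhibition, read by sulforhodamine B assay, with a stated time of 72 h (on this read-out lower numbers stand for stronger inhibition and higher numbers for weaker inhibition), compound 1 (`COc1cc2c(Nc3ccc(F)c(Cl)c3)ncnc2cc1OCCOCCn1ccnc1[N+](=O)[O-]`) gives 9860 nM and compound 2 (`COc1cc2c(Nc3cccc(Br)c3)ncnc2cc1OCCCn1ccnc1[N+](=O)[O-]`) gives 10900 nM, so these two values lie within the scatter of each other. Compound 3 (`COc1cc2c(Nc3cccc(Br)c3)ncnc2cc1OCCOCCn1ccnc1[N+](=O)[O-]`) keeps the shared core of compound 2 and alters only the chain that ends in the nitroimidazole: 2-(2-nitro-1H-imidazol-1-yl)ethoxy in place of (2-nitro-1H-imidazol-1-yl)methyl on a saturated chain carbon, two bonds along the chain from an oxygen on an aromatic ring. Going by the values given here, no measured pair of compounds isolates this change, so no step beyond the scatter is expected in this assay. The estimated change is a 1.1-fold lower number from compound 2 to compound 3 (0.06 log units; within the scatter). For compound 3, the expected value is 9500 nM, with an estimated range of 4000 nM to 22000 nM.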

Compound 3, half-maximal inhibitory concentration: 10800 nM
Compound 3: the middle estimate sits 1.1-fold (0.06 log units) below what was measured; the measured number falls inside the stated range.
By their numbers in this assay, from the lowest: compounds 1, 3 and 2 (each within the scatter of the next).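

Placing 2-(2-nitro-1H-imidazol-1-yl)ethoxy in place of (2-nitro-1H-imidazol-1-yl)methyl on this saturated chain carbon gives a 1.0-fold lower number from compound 2 to compound 3 (0.00 log units; within the scatter) in this assay, so the larger chain end leaves the number within the scatter. Placing 3-bromophenyl in place of 3-chloro-4-fluorophenyl on a nitrogen on an aromatic ring gives a 1.1-fold higher number from compound 1 to compound 3 (0.04 log units; within the scatter), so neither change registers here. Nothing available gives a reason for this lack of response. Still open, on these data alone, is whether an amine or a carboxylic acid in place of the nitroimidazole, or a longer chain, would move the number beyond the scatter.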